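Removing the nitro group from a sulfonyl-linked anilide

This account rests on a few compounds, and the source may have more. Where it says the series, first, only, none or still open, it means among the compounds named here.

Measured compounds: compound 1 `O=C(Nc1ccc([N+](=O)[O-])c(C(F)(F)F)c1)c1ccc(Sc2ccc(O)cc2)cc1` gives 3580 nM in a functional assay on LNCaP cells (Homo sapiens) for antiproliferative activity, read by fluorescence and propidium iodide staining, with a stated time of 96 h; a lower number here means a stronger inhibitor, a higher number a weaker inhibitor; compound 2 `O=C(Nc1ccc([N+](=O)[O-])c(C(F)(F)F)c1)c1ccc(S(=O)(=O)c2ccc(O)cc2)cc1` gives 4960 nM in this assay.

For the measured compounds named here, compound 2 holds the highest of the two numbers, and its only neighbour is compound 1, the step of a 1.4-fold higher number from compound 1 to compound 2 (0.14 log units; within the scatter) lying within the scatter. Compound 3 `O=C(Nc1cccc(C(F)(F)F)c1)c1ccc(S(=O)(=O)c2ccc(O)cc2)cc1` differs from compound 2 by hydrogen in place of nitro on an aromatic carbon. Going by the values given here, no measured step touches this position, so the only measured step gives no guide. Compound 3 is expected to be weaker, with a step of a 2.4-fold higher number from compound 2 to compound 3 (0.38 log units; beyond the scatter). Compound 3 is thus estimated at 12000 nM, within a range of 3000 nM to 50000 nM.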

Compound 3, half-maximal inhibitory concentration: 10200 nM
The estimate for compound 3 lay 1.2-fold (0.07 log units) above the measured number; measured number inside the range.
By their numbers in this assay, from the lowest: compounds 1 and 2 (each within the scatter of the next); then compound 3.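

In this assay, hydrogen in place of nitro on the aromatic carbon ortho to a trifluoromethyl group gives a 2.1-fold higher number from compound 2 to compound 3 (0.31 log units; beyond the scatter), a modest step and the first shown here to lie beyond the scatter. The nitro group therefore contributes to the number, yet compound 3 still gives a measurable value without it. Nothing available explains this shift. The compounds shown leave open whether an amine or a nitrile on this carbon would restore the number of compound 2. They also leave open whether the step holds with the sulfanyl link of compound 1.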